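A few compounds are considered here, and "the series" means these few. Any claim that something is new, unique, unknown or untested is made for them only; others in the source may bear on it.

Of the compounds shown here, two built on one shared core have so far been measured in a functional assay on CHO cells for antagonist activity at Orexin receptor type 2 (Homo sapiens), read by FLIPR and calcium flux; a higher number here means a weaker inhibitor, a lower number a stronger inhibitor. Compound 1 `COc1ccc(C)cc1NC(=O)CSc1nnc(-c2ccoc2C)n1Cc1ccco1` gives 15.9 nM, while compound 2 `CC(=O)c1cccc(NC(=O)CSc2nnc(-c3ccoc3C)n2Cc2ccco2)c1` gives 316 nM, so compound 2 stands at the higher of the two numbers. Within the data shown here, the single recorded step, a 20-fold higher number from compound 1 to compound 2 (1.30 log units; beyond the scatter), shows that exchanging the aryl group on the amide-type nitrogen can move the number a long way. Compound 3 `Cc1occc1-c1nnc(SCC(N)=O)n1Cc1ccco1` differs from compound 2 by hydrogen in place of 3-acetylphenyl on an amide-type nitrogen: here the aryl group is not exchanged but removed altogether. Among the measured compounds shown here, only that one measured step bears on this change, and it was large, so an even larger shift toward weaker inhibition is expected rather than a gain. The expected step is a 16-fold higher number from compound 2 to compound 3 (1.20 log units; beyond the scatter), which would place compound 3 near 5000 nM in this assay, with a plausible range from 1000 nM to 30000 nM.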

Compound 3, inhibition constant: > 15800 nM
Compound 3: a limit, no number; the forecaster's own chance of this, stated with the estimate: 40%; at least 3.1-fold (0.49 log units) between middle value and limit.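

Hydrogen in place of 3-acetylphenyl on the amide-type nitrogen gives an at least 50-fold higher number from compound 2 to compound 3 (1.69 log units; beyond the scatter), and hydrogen in place of 2-methoxy-5-methylphenyl gives an at least 990-fold higher number from compound 1 to compound 3 (2.99 log units; beyond the scatter). Compound 3 carries a limit and not a number: the limit of > 15800 nM in this assay, at which 1 of the 3 values shown sits. Among these compounds, the earlier step compared only one aryl group with another, whereas now the two compounds with an aryl group on this nitrogen give numbers and the one with hydrogen there gives none, so the full size of the loss cannot be told.

Left open is whether a simple methyl or a cyclohexyl group on this nitrogen would give a number nearer to compound 1 or to compound 3. Also open, from the compounds shown here alone, is how much of the gap between compound 1 and compound 2 belongs to the methoxy group, the methyl group or the acetyl group.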